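Ethoxy in Place of Allyloxy on the Chromanone Core

The source may report more compounds than this note shows. Statements on the series, on what has been measured and on what is new or still open speak of the compounds shown alone.

Measured compounds:
compound 1, `C=CCOc1ccccc1C1CC(=O)c2ccccc2O1`: 38600 nM
compound 2, `O=C1CC(c2ccccc2OCc2ccc(F)cc2)Oc2ccccc21`: 25500 nM

In a functional assay on J774.A1 cells (Mus musculus) for inhibition, read by Griess assay, with stated times of 1 h and 24 h (a lower number here means a stronger inhibitor, a higher number a weaker inhibitor), compound 1 stands highest of the two numbers; its nearest neighbour is compound 2, and the step from compound 1 to compound 2 is a 1.5-fold lower number from compound 1 to compound 2 (0.18 log units; within the scatter), so the two are not separated. Compound 3, `CCOc1ccccc1C1CC(=O)c2ccccc2O1`, has not yet been measured in this assay. It differs from compound 1 by methyl in place of vinyl on a saturated chain carbon bound to an oxygen on an aromatic ring. Going by the values given here, the only measured step that bears on this site is the one from compound 1 to compound 2, a 1.5-fold lower number from compound 1 to compound 2 (0.18 log units; within the scatter), where a different group entered on the same saturated chain carbon bound to an oxygen on an aromatic ring and the number hardly moved. On that basis no step beyond the scatter is expected in this assay for compound 3. Compound 3 is therefore estimated at 40000 nM, with a range from 15000 nM to 100000 nM. This estimate corresponds to an expected step of a 1.0-fold higher number from compound 1 to compound 3 (0.02 log units; within the scatter).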

Compound 3, half-maximal inhibitory concentration: 38800 nM
Beside the measured number, compound 3's estimate is 1.0-fold (0.01 log units) above it, and the stated range covers the measured number.
By their numbers in this assay, from the lowest: compounds 2, 1 and 3 (each within the scatter of the next).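

In this assay, ethoxy in place of allyloxy gives a 1.0-fold higher number from compound 1 to compound 3 (0.00 log units; within the scatter) and so shows that losing the double bond of the allyl group leaves the number unmoved at this position. The second new step, a 1.5-fold higher number from compound 2 to compound 3 (0.18 log units; within the scatter), sets methyl against 4-fluorophenyl on the same saturated chain carbon bound to an oxygen on an aromatic ring, and with vinyl that makes three groups that the assay does not separate. The data shown offer no measurement that accounts for this flat reading.

From the compounds shown here alone, whether an amine or a carboxylic acid on this chain, or a bare hydroxyl with the chain gone, would give a step beyond the scatter remains open. Going by these compounds, all three compounds also share one core, so what a change on the core itself would do stays open as well.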